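The source may hold more compounds than are shown below. What is called first, only, known or untested is meant among the compounds shown, and "the series" means these compounds.

Measured in an ADME assay on HEK-293T cells (Homo sapiens) for cytotoxicity, read by CCK-8 assay, with a stated time of 48 h; on this read-out lower numbers stand for stronger inhibition and higher numbers for weaker inhibition:
- Compound 1 `O=S(=O)(NCCNC(=S)Nc1cccc(Cl)c1)c1ccc(-c2ccccc2OCc2cccc(O)c2)s1`: 17400 nM
- Compound 2 `O=[N+]([O-])c1ccc(NC(=S)NCCNS(=O)(=O)c2ccc(-c3ccccc3OCc3cccc(O)c3)s2)cc1`: > 20000 nM
- Compound 3 `COc1ccc(NC(=O)NCCNS(=O)(=O)c2ccc(-c3ccccc3Oc3ccc([N+](=O)[O-])cc3)s2)cc1`: > 20000 nM

Compound 3 stands at > 20000 nM, which is a limit of the assay and not a number. As far as these compounds go, it therefore belongs with the readings at the limit of > 20000 nM in this assay, at which 2 of the 3 values shown sit, and its true value remains unknown.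

Compound 4 `COc1ccc(NC(=O)NCCNS(=O)(=O)c2ccc(-c3ccccc3OCc3cccc(O)c3)s2)cc1` follows from compound 3 by one change: 3-hydroxybenzyl in place of 4-nitrophenyl on an oxygen on an aromatic ring, (3-hydroxybenzyl in place of 4-nitrophenyl on an oxygen on an aromatic ring). For the measured compounds named here, no measured step covers this change. The only one available, an at least 1.1-fold higher number from compound 1 to compound 2 (0.06 log units; that floor lies within the scatter), swaps 4-nitrophenyl for 3-chlorophenyl at another place, on an amide-type nitrogen, and its floor lies within the scatter. It offers only weak, indirect guidance.

The closest evidence comes from the two compounds that already carry 3-hydroxybenzyl on that oxygen. Compound 1 gives 17400 nM in this assay. Compound 2 gives > 20000 nM, again a limit. On the strength of compound 1 at 17400 nM, no large move is expected, and the estimated step, an at least 1.0-fold lower number from compound 3 to compound 4 (0.02 log units; that floor lies within the scatter), is expected to stay within the scatter. For compound 4 the estimated value is 19000 nM, with an expected range of 9000 nM to 40000 nM.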

Compound 4, half-maximal inhibitory concentration: > 20000 nM
Compound 4 gave a limit, no number; the forecaster's own chance of this, stated with the estimate: 55%; middle value at least 1.0-fold (0.02 log units) from the limit.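

In this assay compound 4 gives > 20000 nM, which is a limit of the assay and not a number, and it joins the other readings held there: the limit of > 20000 nM in this assay, at which 3 of the 4 values shown sit. The change from 4-nitrophenyl to 3-hydroxybenzyl on this oxygen on an aromatic ring therefore brings no number into view, and the steps to compound 4 from compound 3 and from compound 2 cannot be read. The only readable step is an at least 1.1-fold higher number from compound 1 to compound 4 (0.06 log units; that floor lies within the scatter), which comes with a change of the group on the amine nitrogen and leaves compound 1 as the only one of these compounds with an actual number.

The compounds shown leave open how large the effect of either change is, since the true values behind the limits remain unknown. As far as these compounds go, it also remains open whether another group on that oxygen, such as 3-aminobenzyl or a benzyl carrying a carboxylic acid, would give a number in this assay rather than a limit.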